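This account rests on a few compounds, and the source may have more. Where it says the series, first, only, none or still open, it means among the compounds named here.

Measured compounds:
- compound 1, `CN1CCN(CCCN(C(=O)Nc2ccc(F)c(Cl)c2)C2CCc3ccccc3C2)CC1`: 380 nM
- compound 2, `COc1ccc2c(c1)CC(N(CCCN1CCN(C)CC1)C(=O)Nc1ccc(F)c(Cl)c1)CC2`: 92 nM
- compound 3, `CN1CCN(CCCN(C(=O)Nc2ccc(F)c(Cl)c2)C2CCc3ccc(N)cc3C2)CC1`: 260 nM

All three share one core and differ only in a single substituent on an aromatic carbon. In an assay on CHO cells for binding affinity to melanin-concentrating hormone receptor 1 (Homo sapiens) (a lower number here means a stronger inhibitor, a higher number a weaker inhibitor), compound 3 gives 260 nM and stands second highest of the three numbers: the nearest of the other numbers is reached by a 1.5-fold lower number from compound 1 to compound 3 (0.16 log units; within the scatter), while compound 2 sits further away, with a 2.8-fold higher number from compound 2 to compound 3 (0.45 log units; beyond the scatter).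

Compound 4, `CC(C)C(=O)Nc1ccc2c(c1)CC(N(CCCN1CCN(C)CC1)C(=O)Nc1ccc(F)c(Cl)c1)CC2`, is the next step from compound 3. The change is isopropylcarbonyl in place of hydrogen on a nitrogen on an aromatic ring; read one bond further out, the amino group becomes an (isopropylcarbonyl)amino group. For the measured compounds named here, none of the measured steps replaces a hydrogen on that nitrogen, so no step bears on it directly. The nearest guide is a 4.1-fold lower number from compound 1 to compound 2 (0.62 log units; beyond the scatter), where a larger group at this aromatic position gave a lower number, together with a 1.5-fold lower number from compound 1 to compound 3 (0.16 log units; within the scatter), where the bare amino group changed little. Adding a five-heavy-atom group onto the amino nitrogen is therefore expected to shift this assay at most modestly, more likely toward a lower number, so for compound 4 the estimate is a 1.6-fold lower number from compound 3 to compound 4 (0.21 log units; within the scatter), giving 160 nM with a range from 50 nM to 500 nM.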

Compound 4, inhibition constant: 61 nM
Compound 4: middle estimate off by 2.6-fold (0.42 log units), on the high side; the range from low to high includes it.
By their numbers in this assay, from the lowest: compounds 4 and 2 (each within the scatter of the next); then compounds 3 and 1 (each within the scatter of the next).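

In this assay, placing isopropylcarbonyl on the amino nitrogen has an effect that the bare amino group did not show, giving a 4.3-fold lower number from compound 3 to compound 4 (0.63 log units; beyond the scatter). Set against the core with only hydrogen at this aromatic carbon, the full (isopropylcarbonyl)amino group gives a 6.2-fold lower number from compound 1 to compound 4 (0.79 log units; beyond the scatter), so the position accepts a group of this size and the number still falls well beyond the scatter. Exchanging methoxy for (isopropylcarbonyl)amino gives a 1.5-fold lower number from compound 2 to compound 4 (0.18 log units; within the scatter), which is within the scatter, so these two different groups cannot be separated in this assay, while the free amino group stays within the scatter of plain hydrogen.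

On these data alone, it remains open whether the number would hold or keep falling with a longer chain, a cyclopropyl or a phenyl ring on the carbonyl, or with a methyl group on the amide nitrogen in place of the amide hydrogen. Nothing in the available data gives a reason for the differences between these compounds.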